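The source may report more compounds than this note shows. Statements on the series, on what has been measured and on what is new or still open speak of the compounds shown alone.

Three compounds have been measured in an ADME assay on microsomes from liver (Homo sapiens) for metabolic stability, read by LC-MS, with a stated time of 10 min, tested at 0.5 uM; a higher number here means that more of the compound is left, a lower number that less of the compound is left:

compound 1, `c1cnc(CN(CCCN2CCNCC2)[C@H]2CCCc3cccnc32)nc1`, gives 100%
compound 2, `CC(C)N1CCN(CCCN(C[C@H]2Cc3ccccc3CN2)[C@H]2CCCc3cccnc32)CC1`, gives 46%
compound 3, `CCN1CCN(CCCN(C[C@H]2Cc3ccccc3CN2)[C@H]2CCCc3cccnc32)CC1`, gives 59%

Among these three numbers compound 1 stands highest in this assay; compound 3 is nearest, and compound 2 is furthest from it, both beyond the scatter. Among the compounds with values here, the only step between two measured compounds is the one from compound 2 to compound 3, where a number 13 percentage points higher from compound 2 to compound 3 (beyond the scatter); it concerns hydrogen in place of methyl on a saturated chain carbon bound to an amine nitrogen in a ring and a saturated chain carbon.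

Compound 4, `c1cnc2c(c1)CCC[C@@H]2N(CCCN1CCNCC1)Cc1cc2ccccc2cn1`, has not yet been measured in this assay. It differs from compound 1 in one place: isoquinolin-3-yl in place of pyrimidin-2-yl on a saturated chain carbon bound to an amine nitrogen. Within the data shown here, no measured step touches an exchange of this kind, so the data give no direct guide to its size or direction. Since compound 1 already sits at the top of the measured range with 100%, the step from compound 1 to compound 4 is expected to be a number 25 percentage points lower from compound 1 to compound 4 (beyond the scatter), downward rather than upward if anything. The estimate for compound 4 in this assay is 75%, with a range from 40% to 100%.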

Compound 4, percent of the compound remaining: 66%
Compound 4: the middle estimate sits 9 percentage points above what was measured; measured number inside the range.
By their numbers in this assay, from the lowest: compound 2; then compounds 3 and 4 (each within the scatter of the next); then compound 1.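

In this assay, the exchange of pyrimidin-2-yl for isoquinolin-3-yl on a saturated chain carbon bound to an amine nitrogen gives a number 34 percentage points lower from compound 1 to compound 4 (beyond the scatter) and so is a large step, with the rest of the molecule unchanged. This shows that the group at this place matters, and that the top value of compound 1 does not carry over to every aromatic group there. The change replaces one six-membered aromatic ring with 2 hetero atoms by a group with an added six-membered aromatic ring of carbon only, but no measurement here gives a reason for the drop.

Two things change at once, the number of rings and the number of ring nitrogens, so the compounds shown cannot tell which of them goes with the lower number. A pyridin-2-yl group at the same place, with a single ring and one ring nitrogen, would help to separate the two.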